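The source may report more compounds than this note shows. Statements on the series, on what has been measured and on what is new or still open speak of the compounds shown alone.

Compound 1 `CC(NC(=O)[C@H](CCCCN)NC(=O)[C@H](CCCNC(=N)N)NC(=O)c1ccccc1)(C(N)=O)c1ccccc1` is measured in an assay on isolated protein for inhibition of Trypsin (Homo sapiens), read by fluorescence, with a stated time of 15 min, tested at 50 uM (on this read-out lower numbers stand for less inhibition and higher numbers for more inhibition at the one concentration tested (going by the name of the read-out)), and gives <= 5%, a limit of the assay and not a number. Compound 2 `C[C@@](NC(=O)[C@H](CCCCN)NC(=O)[C@H](CCCNC(=N)N)NC(=O)c1ccccc1)(C(N)=O)c1ccccc1` in this assay gives 20.7%; the step of a number at least 15.7 percentage points higher from compound 1 to compound 2 (beyond the scatter) rests on a drawn configuration alone, as the limit of <= 5% in this assay, at which 1 of the 2 values shown sits, and the fact that one of compounds 1 and 2 is drawn with a defined configuration and the other without, at the place where they differ show. Compound 3 `N=C(N)NCCC[C@H](NC(=O)c1ccccc1)C(=O)N[C@@H](CCCCN)C(=O)NC(C(N)=O)(c1ccccc1)c1ccccc1` differs from compound 1 by phenyl in place of methyl on a saturated chain carbon bound to an amide-type nitrogen, an aromatic carbon and a carbonyl carbon. Among the measured compounds shown here, no measured step covers this change, so no step beyond the scatter in this assay is expected in either direction, and the estimated step is a number no lower from compound 1 to compound 3 (the limit leaves the size open). Compound 3 is therefore expected to give 5% in this assay, within 0% to 20%.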

Compound 3, a percentage reported as inhibition, at one concentration (the size of the read-out at that concentration, not a potency): 45.5%
Beside the measured number, compound 3's estimate is 40.5 percentage points below it; measured number above the stated range.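

The earlier compounds shown here varied only the drawn configuration at the saturated chain carbon bound to an amide-type nitrogen, an aromatic carbon and a carbonyl carbon. Here the group itself changes: in this assay, phenyl in place of methyl gives a number at least 40.5 percentage points higher from compound 1 to compound 3 (beyond the scatter). Compound 1 stands at a limit of the assay and not at a number, so the step has only a lower bound: the limit of <= 5% in this assay, at which 1 of the 3 values shown sits.

The compounds shown leave open how a benzyl or cyclohexyl group at this place would read in this assay. They also leave open whether an aromatic ring is needed there.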